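The compounds below may be only part of what the source reports. "The series", "measured", "known", "first", "only" and "open" are said of these compounds alone.

Series notes. Compound 1 `Cc1cc(Nc2nc(NCc3ccc(F)cc3F)nc3ccccc23)n[nH]1` in an assay for inhibition of high affinity nerve growth factor receptor (Homo sapiens), read by HTRF, with a stated time of 30 min, in the presence of a further agent that is not named here (on this read-out higher numbers stand for weaker inhibition and lower numbers for stronger inhibition), gives 200 nM. Compound 2 `Cc1cc(Nc2nc(NCc3ccc(F)cc3F)nc3ccc(F)cc23)n[nH]1` in this assay gives 44 nM; the two differ only in that compound 2 carries fluoro in place of hydrogen on an aromatic carbon of the core, and this single change gives a 4.5-fold lower number from compound 1 to compound 2 (0.66 log units; beyond the scatter). On the two numbers shown so far compound 2 therefore stands lowest, with compound 1 as its only neighbour at a higher number.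

Compound 3 `Cc1cc(Nc2nc(NCc3ccc(F)cc3F)nc3ccc(Cl)cc23)n[nH]1` is not yet measured. Relative to compound 2 it shows (chloro in place of fluoro on an aromatic carbon), the change sitting on an aromatic carbon of a six-membered aromatic ring of carbon only, part of a fused system of two rings, meta to a fused ring and para to a fused ring. Within the data shown here, the only measured step that touches this carbon is the one from compound 1 to compound 2, which replaced hydrogen rather than fluoro and was modest in size. Among the measured compounds shown here, no step from fluoro to chloro has been measured, so the expectation for compound 3 rests on that one step alone. For compound 3 in this assay the number is expected to sit near that of compound 2, so that the estimated step of a 1.3-fold lower number from compound 2 to compound 3 (0.10 log units; within the scatter) would stay within the scatter. The estimate for compound 3 is 35 nM, with a range from 12 nM to 110 nM.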

Compound 3, half-maximal inhibitory concentration: 520 nM
Compound 3: the middle estimate sits 15-fold (1.17 log units) below what was measured; the measured number lies above the stated range.
By their numbers in this assay, from the lowest: compound 2; then compound 1; then compound 3.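

In this assay this carbon proves sensitive to which halogen it carries, and not only to whether it carries one: chloro in place of fluoro gives a 12-fold higher number from compound 2 to compound 3 (1.07 log units; beyond the scatter) and is a large step in the series. Chloro in place of hydrogen gives a 2.6-fold higher number from compound 1 to compound 3 (0.41 log units; beyond the scatter) and so runs opposite in direction to the fluoro step a 4.5-fold lower number from compound 1 to compound 2 (0.66 log units; beyond the scatter) from the same parent, which means that halogen substitution at this carbon has no single direction across these compounds, with compound 2 on one side of compound 1 and compound 3 on the other. Nothing at hand bears on why fluoro and chloro part so sharply on this carbon.

From the compounds shown here alone, it remains open whether a methyl, a methoxy or a nitrile on this carbon would fall with fluoro, with chloro or with neither. Going by these compounds, it also remains open whether the difference between fluoro and chloro holds with another group in place of the 2,4-difluorobenzyl amine on the shared core, such as a plain benzyl amine.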